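Furan to Thiophene on the Saturated Ring Carbon

This account rests on a few compounds, and the source may have more. Where it says the series, first, only, none or still open, it means among the compounds named here.

Measured compounds:
compound 1, `CC1=C(C(=O)OC(C)(C)C)C(c2ccsc2)NC(=O)N1`, 1%
compound 2, `CC1=C(C(=O)OCc2ccccc2)C(c2ccsc2)NC(=O)N1`, 25%
compound 3, `CC1=C(C(=O)OCC2CC2)C(c2ccoc2)NC(=O)N1`, 3%

Of the compounds shown here, three sharing one core have been tested in an assay on membranes from HeLa cells for displacement of a labelled ligand from adenosine receptor A3 (Homo sapiens), read by scintillation counting, with a stated time of 180 min, tested at 1 uM; on this read-out higher numbers stand for more inhibition at the one concentration tested (going by the name of the read-out) and lower numbers for less inhibition. Compound 3 stands second highest of the three numbers: its nearest neighbour is compound 1, which is within the scatter of it, and its furthest is compound 2, which lies beyond the scatter above it. Within the data shown here, the one step that can be computed between measured compounds is a number 24 percentage points higher from compound 1 to compound 2 (beyond the scatter), and that change concerns the group on the oxygen next to the carbonyl group, not the saturated ring carbon.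

Compound 4, `CC1=C(C(=O)OCC2CC2)C(c2ccsc2)NC(=O)N1`, has not yet been measured. It differs from compound 3 in one place: thiophen-3-yl in place of furan-3-yl on a saturated ring carbon. Among the measured compounds shown here, no measured pair shows this exchange, so no step in this assay bears on it directly. What the numbers do show is that compound 1, which carries thiophen-3-yl on that same saturated ring carbon, and compound 3, which carries furan-3-yl there, give values within the scatter of each other. On that basis compound 4 is expected to stay close to compound 3, with a step of a number 2 percentage points higher from compound 3 to compound 4 (within the scatter) that is not expected to exceed the scatter. The estimate for compound 4 in this assay is 5%, with a range from 0% to 16%.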

Compound 4, a percentage reported as inhibition, at one concentration (the size of the read-out at that concentration, not a potency): 3%
Compound 4: the middle estimate sits 2 percentage points above what was measured; measured number inside the range.
By their numbers in this assay, from the lowest: compounds 1, 3 and 4 (each within the scatter of the next); then compound 2.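

In this assay, the exchange of furan-3-yl for thiophen-3-yl on the saturated ring carbon now has a direct pair, with cyclopropylmethyl held fixed on the oxygen next to the carbonyl group: no change at the digits printed from compound 3 to compound 4 (within the scatter). At this position the two rings cannot be told apart in this pair, though the pair sits at the low end of the numbers shown and says nothing about how the exchange reads where inhibition is greater. With thiophen-3-yl held fixed, compound 4 also completes a series on that oxygen: there is a number 22 percentage points lower from compound 2 to compound 4 (beyond the scatter), yet a number 2 percentage points higher from compound 1 to compound 4 (within the scatter), so among benzyl, cyclopropylmethyl and tert-butyl only the benzyl compound stands apart, and no measurement at hand accounts for these numbers.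

Among these compounds, the exchange is seen only with cyclopropylmethyl on the oxygen, so whether furan-3-yl and thiophen-3-yl would also match with benzyl there remains open. Also open is what a pyridin-3-yl group on the saturated ring carbon, or a phenethyl group on the oxygen, would give, and how any of these compounds would read as a full potency rather than at one concentration.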